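This account rests on a few compounds, and the source may have more. Where it says the series, first, only, none or still open, it means among the compounds named here.

In a functional assay on DU-145 cells (Homo sapiens) for inhibition, read by trypan blue exclusion, with a stated time of 96 h (a lower number here means a stronger inhibitor of growth, a higher number a weaker inhibitor of growth), compound 3 (`O=C(/C(=C\c1ccc(F)cc1Cl)Sc1ccc(Br)cc1)c1ccc(Br)cc1`) gives 1000 nM and stands level with compound 1 (`COc1cc(/C=C(/Sc2ccc(Br)cc2)C(=O)c2ccc(Br)cc2)ccc1O`), which gives 1000 nM at the digits shown. Together they hold the lowest of the three numbers, while compound 2 (`COc1ccc(/C=C(/Sc2ccc(Br)cc2)C(=O)c2ccc(Br)cc2)c(F)c1`) gives 20000 nM and lies furthest off. Compound 4 (`O=C(/C(=C\c1ccc(Cl)cc1)Sc1ccc(Br)cc1)c1ccc(Br)cc1`) changes compound 3 at one place, on a double-bonded chain carbon bound to a double-bonded chain carbon: 4-chlorophenyl in place of 2-chloro-4-fluorophenyl (4-chlorophenyl in place of 2-chloro-4-fluorophenyl on a double-bonded chain carbon bound to a double-bonded chain carbon). Among the compounds with values here, no measured step makes this exact swap, but three steps change the group at this same place. Two are large (a 20-fold higher number from compound 1 to compound 2 (1.30 log units; beyond the scatter)) and (a 20-fold lower number from compound 2 to compound 3 (1.30 log units; beyond the scatter)), and both involve the 2-fluoro-4-methoxyphenyl of compound 2, which compound 4 does not carry. The third stays within the scatter (no change at the digits printed from compound 1 to compound 3 (within the scatter)). The expectation in this assay is therefore no change at the digits printed from compound 3 to compound 4 (within the scatter) with no step beyond the scatter and no clear direction. For compound 4 the estimated value is 1000 nM with 250 nM to 5000 nM as the expected range.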

Compound 4, concentration for 50% growth inhibition: 1000 nM
Compound 4: middle estimate and measured number agree at the digits printed; the measured number falls inside the stated range.
By their numbers in this assay, from the lowest: compounds 1, 3 and 4 (each within the scatter of the next); then compound 2.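

In this assay, 4-chlorophenyl at this place on a double-bonded chain carbon bound to a double-bonded chain carbon gives no change at the digits printed from compound 3 to compound 4 (within the scatter), and set against the 4-hydroxy-3-methoxyphenyl group it gives no change at the digits printed from compound 1 to compound 4 (within the scatter), so three different groups now stand level and the fluorine of compound 3 is not needed to hold that level. Within the data shown here, the large step recurs as a 20-fold lower number from compound 2 to compound 4 (1.30 log units; beyond the scatter), which leaves the 2-fluoro-4-methoxyphenyl of compound 2 as the only group of the four apart from the rest. No measurement given here offers a reason for this pattern.

The compounds shown leave open whether a plain phenyl, a pyridine ring, or a phenyl bearing an amine or a carboxylic acid would stay level with compound 4 or fall toward compound 2. They also leave open whether the methoxy group or the fluorine of compound 2 accounts for its step.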